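From Nitro to Chloro on the Shared Core

A few compounds are considered here, and "the series" means these few. Any claim that something is new, unique, unknown or untested is made for them only; others in the source may bear on it.

Of the compounds shown here, three sharing one core have been measured in an ADME assay on Vero cells (Chlorocebus sabaeus) for cytotoxicity, read by MTT assay; on this read-out lower numbers stand for stronger inhibition and higher numbers for weaker inhibition. Compound 1 `C=CCOc1cc(OC)c(C(=O)/C=C/c2cccc(OC)c2)c(OCC=C)c1` gives 142000 nM, compound 2 `C=CCOc1cc(OC)c(C(=O)/C=C/c2ccncc2)c(OCC=C)c1` gives 2800 nM, and compound 3 `C=CCOc1cc(OC)c(C(=O)/C=C/c2ccc([N+](=O)[O-])cc2)c(OCC=C)c1` stands between them at 12600 nM. Compound 4 `C=CCOc1cc(OC)c(C(=O)/C=C/c2ccc(Cl)cc2)c(OCC=C)c1` differs from compound 3 by chloro in place of nitro on an aromatic carbon, with chloro in place of nitro on an aromatic carbon.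

Among the compounds with values here, no measured step makes this exact exchange. The closest evidence comes from replacing the whole aromatic group: a 51-fold lower number from compound 1 to compound 2 (1.71 log units; beyond the scatter), an 11-fold lower number from compound 1 to compound 3 (1.05 log units; beyond the scatter) and a 4.5-fold higher number from compound 2 to compound 3 (0.65 log units; beyond the scatter). Within the data shown here, these steps show that this assay can respond strongly to changes at this end of the molecule, though each alters more than the single group exchanged here. Among the measured compounds shown here, the only phenyl compound without nitro, compound 1 at 142000 nM, gives the highest number, so a modest rise is expected. The expected change is a 2.4-fold higher number from compound 3 to compound 4 (0.38 log units; beyond the scatter). For compound 4 the estimated value is 30000 nM, with an expected range from 6000 nM to 120000 nM.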

Compound 4, half-maximal inhibitory concentration: 10400 nM
Beside the measured number, compound 4's estimate is 2.9-fold (0.46 log units) above it; measured number inside the range.
By their numbers in this assay, from the lowest: compound 2; then compounds 4 and 3 (each within the scatter of the next); then compound 1.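

In this assay, the one exchange shown that is confined to this single group, on an aromatic carbon para to a large group, gives a 1.2-fold lower number from compound 3 to compound 4 (0.08 log units; within the scatter) and so does not separate chloro from nitro at this place. The wider exchanges remain beyond the scatter, with a 3.7-fold higher number from compound 2 to compound 4 (0.57 log units; beyond the scatter) and a 14-fold lower number from compound 1 to compound 4 (1.14 log units; beyond the scatter) in the same directions as the steps from those two compounds to compound 3, so among these compounds the large differences go with the whole aromatic group rather than with the choice of chloro or nitro. Nothing independent of these numbers bears on why chloro and nitro read alike here.

On these data alone, whether an amine or a carboxylic acid on this aromatic carbon would also fall with chloro and nitro remains open. As far as these compounds go, it is also open whether 4-methoxyphenyl would read near compound 1 or near compound 4.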